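A few compounds are considered here, and "the series" means these few. Any claim that something is new, unique, unknown or untested is made for them only; others in the source may bear on it.

Three close relatives of one shared core have been measured in an assay on the whole organism (plasma, strain Sprague-Dawley) for inhibition of Dipeptidyl peptidase 4 (Rattus norvegicus), with a stated time of 6 h, at a dose of 1 mg/kg by the oral route; a lower number here means less inhibition, a higher number more inhibition at the dose given (going by the name of the read-out). Compound 1 `CCC[C@@H]1CN[C@H](C(=O)N2CCC[C@H]2C#N)C1` gives 50% and compound 2 `N#C[C@@H]1CCCN1C(=O)[C@@H]1C[C@H](CO)CN1` gives 64% while compound 3 `CCNC(=O)[C@@H]1CN[C@H](C(=O)N2CCC[C@H]2C#N)C1` gives 60%. Compound 3 thus sits second highest of the three, within the usual scatter of both neighbours. Compound 4 `N#C[C@@H]1CCCN1C(=O)[C@@H]1C[C@H](CCO)CN1` differs from compound 3 in one place: 2-hydroxyethyl in place of ethylcarbamoyl on a saturated ring carbon. Among the measured compounds shown here, two measured steps bear on this. Hydroxy in place of ethyl gave a number 14 percentage points higher from compound 1 to compound 2 (beyond the scatter) and ethylcarbamoyl in place of hydroxymethyl gave a number 4 percentage points lower from compound 2 to compound 3 (within the scatter). Compound 4 carries a 2-hydroxyethyl, close kin to the hydroxymethyl of compound 2 with its 64%. For compound 4 the expected step is a number 3 percentage points higher from compound 3 to compound 4 (within the scatter) which is small and likely within the scatter. Compound 4 is therefore estimated at 63% with a range from 49% to 77%.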

Compound 4, a percentage reported as inhibition, in the whole organism at one dose (the size of the read-out at that dose, not a potency): 64%
Compound 4: the middle estimate sits 1 percentage points below what was measured, within the range that was stated.
By their numbers in this assay, from the lowest: compounds 1, 3, 2 and 4 (each within the scatter of the next, the first and the last beyond it).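

In this assay, 2-hydroxyethyl in place of ethylcarbamoyl on this saturated ring carbon gives a number 4 percentage points higher from compound 3 to compound 4 (within the scatter), so the two groups cannot be told apart here. Going from hydroxymethyl to 2-hydroxyethyl gives no change at the digits printed from compound 2 to compound 4 (within the scatter), so these two chain lengths cannot be told apart either. Hydroxy in place of methyl on the chain gives a number 14 percentage points higher from compound 1 to compound 4 (beyond the scatter), which shows on a second chain the rise already seen when a hydroxy-bearing chain replaced propyl.

Nothing available explains these steps. Still open, on these data alone, is whether an amine, a carboxylic acid or a longer chain bearing a hydroxy would reach the same level.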